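Pyrimidinyl for pyridinyl on the piperazine of compound 3

This account rests on a few compounds, and the source may have more. Where it says the series, first, only, none or still open, it means among the compounds named here.

Compound 1 `CC(=O)N1CCN(c2nc(Nc3ccc(C#N)c(C(F)(F)F)c3)nc(Oc3ccnc4ccccc34)n2)CC1` was tested in a functional assay on DU-145 cells (Homo sapiens) for cytotoxicity, read by sulforhodamine B assay, with a stated time of 48 h (on this read-out higher numbers stand for weaker inhibition of growth and lower numbers for stronger inhibition of growth), and gives a value that is a limit of the assay, > 100000 nM. Compound 2 `CC1CC(C)CN(c2nc(Nc3ccc(C#N)c(C(F)(F)F)c3)nc(Oc3ccnc4ccccc34)n2)C1` gives 68000 nM in this assay. Compound 3 `N#Cc1ccc(Nc2nc(Oc3ccnc4ccccc34)nc(N3CCN(c4ccccn4)CC3)n2)cc1C(F)(F)F` in this assay also gives a limit of the assay, > 100000 nM. Compound 3 thus stands at the upper limit, where one further value also sits (the limit of > 100000 nM in this assay, at which 2 of the 3 values shown sit); only compound 2 gives a number. The steps into compound 3 are a step that the two limits leave unreadable from compound 1 to compound 3 and an at least 1.4-fold higher number from compound 2 to compound 3 (0.16 log units; that floor lies within the scatter).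

Compound 4 `N#Cc1ccc(Nc2nc(Oc3ccnc4ccccc34)nc(N3CCN(c4ncccn4)CC3)n2)cc1C(F)(F)F` differs from compound 3 in one place: pyrimidin-2-yl in place of pyridin-2-yl on an amine nitrogen in a ring. One measured step, a step that the two limits leave unreadable from compound 1 to compound 3, does change the group on that ring nitrogen, but it is not readable; the other steps exchange the whole ring on the aromatic carbon. Going by the values given here, no measured step therefore bears directly on this change, and no movement beyond the scatter is expected in this assay. Compound 4 is expected to give 100000 nM (range 50000 nM to 300000 nM), most probably again as a limit of the assay, which means an expected step of a number no higher from compound 3 to compound 4 (the limit leaves the size open).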

Compound 4, concentration for total growth inhibition: > 100000 nM
Compound 4: only a limit was reported (the forecaster's own chance of this, stated with the estimate: 75%); the middle value sits exactly at the limit.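

In this assay compound 4 gives > 100000 nM, which is a limit of the assay. Going by these compounds alone, the one readable step is an at least 1.4-fold higher number from compound 2 to compound 4 (0.16 log units; that floor lies within the scatter), so the new compound cannot be separated from compound 2 on these data, and the steps from compound 3 and from compound 1 to compound 4 cannot be read. Pyrimidin-2-yl on the amine nitrogen in the ring therefore yields no number, any more than pyridin-2-yl or acetyl did, and the piperazine set stays at the ceiling: the limit of > 100000 nM in this assay, at which 3 of the 4 values shown sit.

As far as these compounds go, it remains open whether any group on that ring nitrogen, such as benzyl or a short chain carrying an amine, would bring a number within the range of the assay. Also open, from the compounds shown here alone, is whether a plain piperidin-1-yl or a morpholin-4-yl on the aromatic carbon would give a number as 3,5-dimethylpiperidin-1-yl does.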